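This account rests on a few compounds, and the source may have more. Where it says the series, first, only, none or still open, it means among the compounds named here.

Of the compounds shown here, three built on related cores have been tested in an ADME assay on HEK293 cells (Homo sapiens) for cytotoxicity, read by MTT assay, with a stated time of 48 h; on this read-out higher numbers stand for weaker inhibition and lower numbers for stronger inhibition. Compound 1 `CCS(=O)(=O)Nc1ccc(NC(=O)c2ccc(C#N)cc2)cc1C` gives > 250000 nM in this assay, a value that is a limit of the assay rather than a number. Compound 2 `Cc1cc(NC(=O)c2ccc(C#N)cc2)ccc1NS(=O)(=O)C(F)(F)F` likewise gives > 250000 nM in this assay, again a limit. The step that the two limits leave unreadable from compound 1 to compound 2 therefore cannot be read, since the limit of > 250000 nM in this assay, at which 2 of the 3 values shown sit, is where both values sit. The change behind that step is trifluoromethyl in place of ethyl on a sulfonyl sulfur. Going by the values given here, compound 3 `CCS(=O)(=O)Nc1ccc(NC(=O)c2cccc(C(F)(F)F)c2)cc1F` gives 94800 nM in this assay, the only plain number among the three; the difference between its core and the core of compound 1 is not broken down here. Compound 4 `O=C(Nc1ccc(NS(=O)(=O)C(F)(F)F)c(F)c1)c1cccc(C(F)(F)F)c1` has not yet been measured. It differs from compound 3 by trifluoromethyl in place of ethyl on a sulfonyl sulfur, the same change as that from compound 1 to compound 2, as the two places are described in the same words. Because the step that the two limits leave unreadable from compound 1 to compound 2 is unreadable, the earlier change offers no size to lean on, and the expectation rests only on compound 3 with its 94800 nM. The step of a 1.3-fold higher number from compound 3 to compound 4 (0.10 log units; within the scatter) is expected to be small. Compound 4 is accordingly estimated at 120000 nM, within a range from 50000 nM to 250000 nM.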

Compound 4, half-maximal inhibitory concentration: 152000 nM
Estimate against measurement, compound 4: 1.3-fold (0.10 log units) below; the range from low to high includes it.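

Trifluoromethyl in place of ethyl on a sulfonyl sulfur gives, in this assay, a 1.6-fold higher number from compound 3 to compound 4 (0.21 log units; within the scatter), so on this core the change leaves no difference that can be told apart from ordinary repeat variation. On the core of compound 1 the same change cannot be read, since compound 1 and compound 2 both rest on a limit of the assay and not on a plain number: the limit of > 250000 nM in this assay, at which 2 of the 4 values shown sit. The change can therefore be read on one core only, so the series does not show whether it behaves alike on the two cores, though nothing shown speaks against that either.

The compounds shown leave open how this assay responds when the sulfonyl sulfur carries something other than ethyl or trifluoromethyl, such as a longer chain like butyl or an amine. As far as these compounds go, no two of them differ by the core alone, so what the core itself contributes also stays open.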